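A few compounds are considered here, and "the series" means these few. Any claim that something is new, unique, unknown or untested is made for them only; others in the source may bear on it.

Measured compounds and their values:
Compound 1 `N#CC1=C(N)Oc2c(c3nc4ccccc4nc3c3ccccc23)C12C(=O)N(Cc1cnnn1-c1ccc(Cl)cc1)c1ccccc12` gives > 50000 nM (a limit of the assay, not a number).
Compound 2 `N#CC1=C(N)Oc2c(c3nc4ccccc4nc3c3ccccc23)C12C(=O)N(Cc1cnnn1-c1ccccc1Br)c1ccccc12` gives > 50000 nM (a limit of the assay, not a number).
Compound 3 `Cc1ccc(-n2nncc2CN2C(=O)C3(C(C#N)=C(N)Oc4c(N)cc5nc6ccccc6nc5c43)c3ccccc32)cc1C` gives > 50000 nM (a limit of the assay, not a number).

All three were tested in an ADME assay on L02 cells (Homo sapiens) for antiproliferative activity, read by MTT assay, with a stated time of 48 h (a lower number here means a stronger inhibitor, a higher number a weaker inhibitor), and none gave a number: the limit of > 50000 nM in this assay, at which 3 of the 3 values shown sit. Compound 3 therefore stands at the limit of this assay, with no number that could be compared. Among the compounds with values here, the only step between measured compounds, a step that the two limits leave unreadable from compound 1 to compound 2, has both ends at that limit, so its size cannot be read.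

Compound 4 `COc1cc(-n2nncc2CN2C(=O)C3(C(C#N)=C(N)Oc4c(N)cc5nc6ccccc6nc5c43)c3ccccc32)c(OC)cc1Cl` has not yet been measured. It differs from compound 3 in one place: 4-chloro-2,5-dimethoxyphenyl in place of 3,4-dimethylphenyl on an aromatic nitrogen. Within the data shown here, no measured step concerns this kind of exchange, and the single measured step gives no size at all, so there is no direct guide to the effect of the change in this assay.

With every measured compound, including compound 3, sitting at the limit, compound 4 is expected to behave in the same way, so the step that the limit leaves unreadable from compound 3 to compound 4 is estimated to be none that can be read beyond the scatter. Compound 4 is accordingly estimated to give 100000 nM in this assay, within 35000 nM to 400000 nM, and is most likely to be reported again only as a limit.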

Compound 4, half-maximal inhibitory concentration: > 50000 nM
Compound 4: no number, only a limit; the forecaster's own chance of this, stated with the estimate: 85%; the middle value does not contradict the limit.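

In this assay compound 4 gives > 50000 nM, a limit of the assay and not a number, so no step can be read between compound 3 and compound 4. All the compounds shown end the same way: the limit of > 50000 nM in this assay, at which 4 of the 4 values shown sit.

The compounds shown leave open whether any group on the aromatic nitrogen would give a real number in this assay.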